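The source may hold more compounds than are shown below. What is called first, only, known or untested is meant among the compounds shown, and "the series" means these compounds.

Measured so far in a functional assay on cells for positive allosteric modulation, with A2780/Taxol (Homo sapiens) as the target, read by MTT assay, with a stated time of 48 h, tested at 10 uM; a lower number here means a stronger inhibitor, a higher number a weaker inhibitor:

- compound 1, `CCOc1ccc2c(C)cc(=O)oc2c1COC(=O)c1ccc(F)cc1`: 64.7 nM
- compound 2, `CCOc1ccc2c(C)cc(=O)oc2c1COC(=O)c1cccc(OC)c1`: 71.2 nM
- compound 3, `CCCc1ccc(C(=O)OCc2c(OCC)ccc3c(C)cc(=O)oc23)cc1`: 74.2 nM

The three measured compounds share one core and differ only in the aryl on the ester carbonyl. Compound 1 carries the lowest number of the three, but the gaps are small: a 1.1-fold higher number from compound 1 to compound 2 (0.04 log units; within the scatter) and a 1.1-fold higher number from compound 1 to compound 3 (0.06 log units; within the scatter) both sit within the scatter, as does a 1.0-fold higher number from compound 2 to compound 3 (0.02 log units; within the scatter). No order among compounds 1, 2 and 3 can be read from these values; changing the ester aryl among 4-fluorophenyl, 3-methoxyphenyl and 4-propylphenyl has left this assay unmoved.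

Compound 4, `Cc1cc(=O)oc2c(COC(=O)c3ccc(F)cc3)c(OC(C)C)ccc12`, keeps the 4-fluorophenyl ester of compound 1 and alters the other side of the core: methyl in place of hydrogen on a saturated chain carbon bound to an oxygen on an aromatic ring and a saturated chain carbon. Cut one bond further out, ethyl becomes isopropyl, ethoxy becomes isopropoxy. For the measured compounds named here, none of the measured steps touches this position; all three vary the ester aryl only, and each stayed within the scatter. There is thus no measured step that bears directly on the change from compound 1 to compound 4, and the series so far has shown no step beyond the scatter for any change at all.

On that basis compound 4 is expected to sit close to compound 1, with a 1.1-fold higher number from compound 1 to compound 4 (0.02 log units; within the scatter) judged to lie within the scatter. The estimate for compound 4 is 68 nM, with a range from 35 nM to 135 nM.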

Compound 4, half-maximal inhibitory concentration: 42.9 nM
Beside the measured number, compound 4's estimate is 1.6-fold (0.20 log units) above it; low and high end bracket the measured number.
By their numbers in this assay, from the lowest: compounds 4, 1, 2 and 3 (each within the scatter of the next).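

In this assay, the change from ethoxy to isopropoxy is the first shown away from the ester aryl, and it gives a 1.5-fold lower number from compound 1 to compound 4 (0.18 log units; within the scatter). This step is larger in size than the three among the ester aryl changes, but it too lies within the scatter, so no order between these two compounds can be read, and the added methyl on this saturated chain carbon has not moved the number beyond the scatter. No measurement shown here offers an explanation for this result.

Still open, from the compounds shown here alone, is whether any change at this position can move the number beyond the scatter, for instance a longer chain such as butoxy, a cyclopentyloxy group, a free hydroxyl or an ether chain ending in an amine. Also open, going by these compounds, is whether isopropoxy behaves the same with the 3-methoxyphenyl and 4-propylphenyl esters, and whether a group such as a carboxylic acid or a pyridine on the ester side would separate from the aryl groups seen so far.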